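Swapping an Unsaturated Ester Chain for a Saturated One

A few compounds are considered here, and "the series" means these few. Any claim that something is new, unique, unknown or untested is made for them only; others in the source may bear on it.

Three esters of the same nucleoside core have been tested in a functional assay on HeLa cells (Homo sapiens) for cytotoxicity, read by cell counting, with a stated time of 48 h; a lower number here means that less compound is needed, a higher number that more compound is needed for the effect. Compound 1 `CCCCCCC/C=C\C(=O)O[C@H]1[C@H](O)[C@H](n2ccc(N)nc2=O)O[C@@H]1CO` carries a chain with one double bond on the ester at its carbonyl carbon, and in this assay compound 1 gives 0.06 ug/mL. Compound 2 `CCCCCCCCCC(=O)OC[C@H]1O[C@@H](n2ccc(N)nc2=O)[C@@H](O)[C@@H]1O` carries its ester on another hydroxyl group of the shared core, and compound 2 gives 0.1 ug/mL; the numbers for compound 1 and compound 2 lie within the usual scatter of each other, so they cannot be told apart. Compound 3 `CCCCCCCC/C=C\CCCCCCCCCCCC(=O)OC[C@H]1O[C@@H](n2ccc(N)nc2=O)[C@@H](O)[C@@H]1OC(=O)CCCCCCCCCCC/C=C\CCCCCCCC` carries two long esters, and for compound 3 the assay reports only a limit at > 10 ug/mL, which is a limit rather than a number (the limit of > 10 ug/mL in this assay, at which 1 of the 3 values shown sits).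

Compound 4 `CCCCCCCCCC(=O)O[C@H]1[C@H](O)[C@H](n2ccc(N)nc2=O)O[C@@H]1CO` is the untested partner of compound 1. a group of 9 heavy atoms (9 carbon; no ring) in place of a group of 9 heavy atoms (9 carbon; no ring), on a carbonyl carbon The chain keeps its length and its place on the carbonyl carbon; only the double bond is gone. For the measured compounds named here, no step of this kind has been measured here, so the expectation rests on the values of compound 1 and compound 2 alone. The step from compound 1 to compound 4 is expected to be a 1.2-fold higher number from compound 1 to compound 4 (0.07 log units; within the scatter), nothing beyond the scatter. Compound 4 is therefore estimated to give 0.07 ug/mL, within a range from 0.03 ug/mL to 0.2 ug/mL.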

Compound 4, concentration for half-maximal effect: 0.09 ug/mL
Compound 4: the middle estimate sits 1.3-fold (0.11 log units) below what was measured; the measured number falls inside the stated range.
By their numbers in this assay, from the lowest: compounds 1, 4 and 2 (each within the scatter of the next). At a limit, above all of these: compound 3.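

At this place, on a carbonyl carbon whose other neighbour is the oxygen of the ester, putting nonyl in place of the unsaturated chain gives a 1.5-fold higher number from compound 1 to compound 4 (0.18 log units; within the scatter) in this assay. This pair is the first shown here that differs in one place only, so it isolates the double bond, which compounds 1 and 2 could not do because their esters sit on different hydroxyl groups and their chains differ as well. At this place and with this chain size, the double bond can go without a change that this assay can tell from the usual scatter, though no measurement shown here bears on the reason for this.

On these data alone, how a longer chain, a shorter chain, or a chain ending in an amine or a carboxylic acid would behave at this place remains open. Compound 3 gives only a limit of > 10 ug/mL, and it differs from compound 4 in more than one place, so it cannot settle what chain length alone does.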